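Swapping the Aryl Substituent on the Shared Core

The source may hold more compounds than are shown below. What is called first, only, known or untested is meant among the compounds shown, and "the series" means these compounds.

Compound 1 `CC(C)=CC/C=C(/C)C/C=N/NC(=O)Nc1nnc(-c2ccc([N+](=O)[O-])cc2)o1` and compound 2 `CC(C)=CC/C=C(/C)C/C=N/NC(=O)Nc1nnc(-c2ccc(F)cc2)o1` share one core and differ only in the group carried on the benzene ring. In a functional assay on the whole organism (strain Swiss albino) with Mus musculus as the target, with a stated time of 4 h (on this read-out lower numbers stand for an effect already at smaller amounts and higher numbers for an effect only at larger amounts of compound), compound 1 gives 300 mg/kg and compound 2 gives 300 mg/kg. The step of no change at the digits printed from compound 1 to compound 2 (within the scatter) shows that exchanging that group left the read-out unchanged, so compound 2 stands level with compound 1 on the numbers at hand. Compound 3 `CC(C)=CC/C=C(/C)C/C=N/NC(=O)Nc1nnc(-c2ccccc2O)o1` brings a different exchange: 2-hydroxyphenyl in place of 4-fluorophenyl on an aromatic carbon. Going by the values given here, only the step from compound 1 to compound 2 bears on this, and it was flat, so the move to compound 3 is expected to give no change beyond the scatter, as no change at the digits printed from compound 2 to compound 3 (within the scatter). The estimate for compound 3 in this assay is therefore 300 mg/kg, with a range from 150 mg/kg to 600 mg/kg to allow for the usual scatter.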

Compound 3, minimum effective dose: 300 mg/kg
Beside the measured number, compound 3's estimate shows no gap at the digits printed; low and high end bracket the measured number.
By their numbers in this assay, from the lowest: compounds 1, 2 and 3 (each within the scatter of the next).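

In this assay, putting 2-hydroxyphenyl on this aromatic carbon gives no change at the digits printed from compound 2 to compound 3 (within the scatter), and measured against the 4-nitrophenyl compound it gives no change at the digits printed from compound 1 to compound 3 (within the scatter). The earlier pair only exchanged one group on the benzene ring for another, whereas 2-hydroxyphenyl also brings a hydrogen-bond donor and a hydrogen-bond acceptor that 4-fluorophenyl lacks, and the read-out still stays level across all three compounds. No measurement at hand offers any explanation for this flat result.

On these data alone, what remains open is whether any group at this place can shift the minimum effective dose at all, since these three aryl groups give no difference to compare. An amine or a carboxylic acid on the benzene ring, or a longer chain in place of the ring, could test this.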